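Trifluorophenyl in place of methoxyphenyl on the cinnamide

The compounds below may be only part of what the source reports. "The series", "measured", "known", "first", "only" and "open" are said of these compounds alone.

Of the compounds shown here, three sharing one core have been tested in a functional assay on COLO 205 cells (Homo sapiens) for cytotoxicity, read by MTT assay, with a stated time of 72 h; on this read-out lower numbers stand for stronger inhibition and higher numbers for weaker inhibition. Compound 1 `COc1cccc(/C=C/C(=O)Nc2cc(C(=O)c3cc(OC)c(OC)c(OC)c3)ccc2OC)c1` gives 5100 nM. Compound 2 `COc1ccc(C(=O)c2cc(OC)c(OC)c(OC)c2)cc1NC(=O)/C=C/c1ccc(F)cc1` carries a 4-fluorophenyl where compound 1 carries a 3-methoxyphenyl; in this assay compound 2 gives 3400 nM, and the step of a 1.5-fold lower number from compound 1 to compound 2 (0.18 log units; within the scatter). Compound 3 `COc1cccc(/C=C/C(=O)Nc2cc(C(=O)c3cc(OC)c(OC)c(OC)c3)cc(OC)c2OC)c1`, which adds a methoxy on an aromatic carbon of the core, gives 10700 nM; the step of a 2.1-fold higher number from compound 1 to compound 3 (0.32 log units; beyond the scatter). Compound 3 therefore stands with the highest number of the three, beyond the usual scatter from both compound 1 and compound 2.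

Compound 4 `COc1cc(C(=O)c2cc(OC)c(OC)c(OC)c2)cc(NC(=O)/C=C/c2cc(F)c(F)c(F)c2)c1OC` keeps the extra methoxy of compound 3 and changes the aryl on the chain: 3,4,5-trifluorophenyl in place of 3-methoxyphenyl on a double-bonded chain carbon bound to a double-bonded chain carbon. For the measured compounds named here, the only measured step that bears on this is the one from compound 1 to compound 2, where a fluorinated phenyl replaced the same 3-methoxyphenyl and the number moved little. On that basis the change from compound 3 to compound 4 is expected to give at most a small step downward, a 1.5-fold lower number from compound 3 to compound 4 (0.18 log units; within the scatter), and possibly none beyond the scatter.

Compound 4 is thus estimated at 7000 nM in this assay, with a range from 2500 nM to 20000 nM.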

Compound 4, half-maximal inhibitory concentration: 4300 nM
Compound 4: middle estimate off by 1.6-fold (0.21 log units), on the high side, within the range that was stated.
By their numbers in this assay, from the lowest: compounds 2, 4 and 1 (each within the scatter of the next); then compound 3.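

In this assay, the replacement of 3-methoxyphenyl by 3,4,5-trifluorophenyl on a double-bonded chain carbon bound to a double-bonded chain carbon gives a 2.5-fold lower number from compound 3 to compound 4 (0.40 log units; beyond the scatter), so a change at this place can move the number beyond the usual scatter, though only modestly. The earlier replacement here, with 4-fluorophenyl entering on the core that lacks the extra methoxy, gave a 1.5-fold lower number from compound 1 to compound 2 (0.18 log units; within the scatter), which did not show this; the two steps differ in both the entering group and the core, so they cannot be set side by side as a clean measure of adding fluorine. No measurement available here explains why the number falls with this change.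

The compounds shown leave open whether the step belongs to 3,4,5-trifluorophenyl itself or depends on the extra methoxy, as that group appears on only one core and 4-fluorophenyl on only the other. They also leave open how a phenyl carrying an amine or a carboxylic acid would read at this same place on the chain.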